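Lengthening the Ester Chain Toward an Octadecyl Carbamate

The source may hold more compounds than are shown below. What is called first, only, known or untested is meant among the compounds shown, and "the series" means these compounds.

Two carbamate esters on a shared core have been tested in an assay on microsomes from intestine for inhibition of acyl-CoA:cholesterol acyltransferase (Oryctolagus cuniculus); on this read-out lower numbers stand for stronger inhibition and higher numbers for weaker inhibition. Compound 1 `CCCCCCOC(=O)NC(=O)Oc1c(C(C)C)cccc1C(C)C` gives 53 nM in this assay. Going by the values given here, compound 2 `CCCCCCCCCCCCOC(=O)NC(=O)Oc1c(C(C)C)cccc1C(C)C` gives 21 nM in this assay, the lower of the two numbers, with compound 1 as its only neighbour. Among the compounds with values here, the one measured step, a 2.5-fold lower number from compound 1 to compound 2 (0.40 log units; beyond the scatter), is a chain extension and was modest but beyond the scatter.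

Compound 3 `CCCCCCCCCCCCCCCCCCOC(=O)NC(=O)Oc1c(C(C)C)cccc1C(C)C` pushes the same idea further: hexyl in place of hydrogen on a saturated chain carbon, ten or more bonds along the chain from an oxygen next to a carbonyl group. Within the data shown here, only the step from compound 1 to compound 2 bears on this change, and it suggests that adding chain length lowers the number somewhat; whether a second extension of the same size brings an equal gain, a smaller one, or nothing beyond the scatter cannot be told from one step. A small further drop is expected, with wide uncertainty. Compound 3 is therefore estimated at 15 nM, within a range of 6 nM to 50 nM. This estimate means an expected step of a 1.4-fold lower number from compound 2 to compound 3 (0.15 log units; within the scatter).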

Compound 3, half-maximal inhibitory concentration: 1000 nM
Compound 3: the middle estimate sits 67-fold (1.82 log units) below what was measured; measured number above the stated range.
By their numbers in this assay, from the lowest: compound 2; then compound 1; then compound 3.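

In this assay, lengthening this ester chain does not keep lowering the number, so the gain seen on the first extension does not carry on. Adding hexyl on a saturated chain carbon gives a 48-fold higher number from compound 2 to compound 3 (1.68 log units; beyond the scatter) and so reverses the direction of the earlier step. Counted from the shortest ester, dodecyl in place of hydrogen gives a 19-fold higher number from compound 1 to compound 3 (1.28 log units; beyond the scatter), which places the octadecyl chain behind the hexyl starting point as well, and no available evidence explains this reversal.

Where between dodecyl and octadecyl the number turns upward remains open, and a tetradecyl or hexadecyl chain would help to locate it. Also open, from the compounds shown here alone, is whether the rise is gradual or abrupt across those lengths.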